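The source may report more compounds than this note shows. Statements on the series, on what has been measured and on what is new or still open speak of the compounds shown alone.

Among the measured compounds shown here, the three compounds measured so far share one core and differ only in the group carried on a saturated chain carbon bound to an aromatic carbon and a saturated chain carbon. Compound 1 `CC(C)C(c1ncco1)c1ccc(-c2ccc3cccc(F)c3c2)[nH]c1=O` gives 64 nM in a functional assay on CHO cells for antagonist activity at prostaglandin E2 receptor EP3 subtype (Homo sapiens), read by cAMP accumulation; on this read-out higher numbers stand for weaker inhibition and lower numbers for stronger inhibition. Compound 2 `CC(C)C(c1ccc(-c2ccc3cccc(F)c3c2)[nH]c1=O)N1CCCCC1=O` gives 40 nM, and compound 3 `CC(C)C(c1nnc[nH]1)c1ccc(-c2ccc3cccc(F)c3c2)[nH]c1=O` gives 21 nM, the lowest of the three numbers; the two steps that lead to it read a 1.9-fold lower number from compound 2 to compound 3 (0.28 log units; within the scatter) and a 3.0-fold lower number from compound 1 to compound 3 (0.48 log units; beyond the scatter). Compound 4 `CC(C)C(c1ncc[nH]1)c1ccc(-c2ccc3cccc(F)c3c2)[nH]c1=O` is not yet measured; it differs from compound 3 in that (1H-imidazol-2-yl in place of 4H-1,2,4-triazol-3-yl on a saturated chain carbon bound to an aromatic carbon and a saturated chain carbon).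

Of the steps seen, only a 3.0-fold lower number from compound 1 to compound 3 (0.48 log units; beyond the scatter) exceeds the scatter, and it concerns a five-membered aromatic ring with three hetero atoms replacing one with two hetero atoms. The new ring of compound 4 again has two hetero atoms, so a small move back toward the number of compound 1 is plausible, but a 1.6-fold lower number from compound 1 to compound 2 (0.20 log units; within the scatter) shows that such swaps can also stay within the scatter. Compound 4 is therefore expected to give roughly 32 nM in this assay, between 13 nM and 80 nM, a step of a 1.5-fold higher number from compound 3 to compound 4 (0.18 log units; within the scatter) that is expected to stay within the scatter.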

Compound 4, half-maximal inhibitory concentration: 33 nM
The estimate for compound 4 lay 1.0-fold (0.01 log units) below the measured number; the measured number falls inside the stated range.
By their numbers in this assay, from the lowest: compounds 3, 4, 2 and 1 (each within the scatter of the next, the first and the last beyond it).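

In this assay, a ring with 2 hetero atoms in place of one with 3 on this saturated chain carbon gives a 1.6-fold higher number from compound 3 to compound 4 (0.20 log units; within the scatter) and so does not measurably shift the number. The other two steps, a 1.2-fold lower number from compound 2 to compound 4 (0.08 log units; within the scatter) and a 1.9-fold lower number from compound 1 to compound 4 (0.29 log units; within the scatter), also stay within the scatter, so compound 4 cannot be separated from any of the other three compounds. The gap between compound 1 and compound 3 remains the only one beyond the scatter, and compound 4 does not tie that gap to the count of hetero atoms in the ring.

Nothing available here explains these numbers. Still open, going by these compounds, is whether a simple amine or a carboxylic acid on this carbon would keep the number in the same range.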